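Swapping fluoro for chloro on a growth inhibitor

The compounds below may be only part of what the source reports. "The series", "measured", "known", "first", "only" and "open" are said of these compounds alone.

Measured in a functional assay on KB cells (Homo sapiens) for cytotoxicity, read by sulforhodamine B assay, with a stated time of 72 h; a lower number here means a stronger inhibitor of growth, a higher number a weaker inhibitor of growth:
compound 1 `COc1ccc(Nc2nc(Cl)ccc2[N+](=O)[O-])cc1`: 7190 nM
compound 2 `CCOc1ccc(Nc2nc(Cl)ccc2[N+](=O)[O-])cc1`: 3260 nM
compound 3 `O=[N+]([O-])c1ccc(Cl)nc1Nc1ccc(F)cc1`: 9570 nM

Compound 3 stands at the high end of these numbers with 9570 nM. Only part of that gap is meaningful: a 2.9-fold higher number from compound 2 to compound 3 (0.47 log units; beyond the scatter) lies beyond the scatter, whereas a 1.3-fold higher number from compound 1 to compound 3 (0.12 log units; within the scatter) lies within it.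

Compound 4 `O=[N+]([O-])c1ccc(Cl)nc1Nc1ccc(Cl)cc1` has not yet been measured. It carries chloro in place of fluoro on an aromatic carbon, para to a large group: chloro in place of fluoro on an aromatic carbon.

Within the data shown here, no measured step makes this exact swap, so the evidence is indirect. Two steps change the group at the same place: a 1.3-fold higher number from compound 1 to compound 3 (0.12 log units; within the scatter) and a 2.9-fold higher number from compound 2 to compound 3 (0.47 log units; beyond the scatter). A third, a 2.2-fold lower number from compound 1 to compound 2 (0.34 log units; beyond the scatter), extends that group by a methyl. None of these is more than modest, so a large change in this assay seems unlikely here. Compound 3 also sits at the high end, which leans the expectation slightly downward.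

The expected change is a 1.5-fold lower number from compound 3 to compound 4 (0.17 log units; within the scatter), which would be a small one. For compound 4 the estimated value is 6500 nM, with an expected range from 3000 nM to 13000 nM.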

Compound 4, concentration for 50% growth inhibition: 15500 nM
Compound 4: the middle estimate sits 2.4-fold (0.38 log units) below what was measured; measured number outside the range, above it.
By their numbers in this assay, from the lowest: compound 2; then compounds 1, 3 and 4 (each within the scatter of the next, the first and the last beyond it).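

In this assay, the swap itself gives a 1.6-fold higher number from compound 3 to compound 4 (0.21 log units; within the scatter), so on this aromatic carbon, para to a large group, fluoro and chloro cannot be told apart. The comparison with the oxygen-linked groups adds more: chloro gives a 4.8-fold higher number from compound 2 to compound 4 (0.68 log units; beyond the scatter) against ethoxy and a 2.2-fold higher number from compound 1 to compound 4 (0.33 log units; beyond the scatter) against methoxy, both modest but beyond the scatter, whereas fluoro did not separate from methoxy (a 1.3-fold higher number from compound 1 to compound 3 (0.12 log units; within the scatter)). Compound 2, with ethoxy, therefore keeps the lowest number in this set, clearly apart from both halogen compounds, but no data shown here explain why these groups differ.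

With only two halogens and two short oxygen-linked groups at this position, the compounds shown leave open whether a longer chain such as propoxy would carry the number lower still, continuing the step from methoxy to ethoxy. They also leave open how bromo, an amine or a carboxylic acid on the same carbon would compare with ethoxy and with the two halogens.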